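A few compounds are considered here, and "the series" means these few. Any claim that something is new, unique, unknown or untested is made for them only; others in the source may bear on it.

Measured so far in an ADME assay on a cell-free system (plasma, Rattus norvegicus) for protein binding:
- compound 1 `Cc1ccc(-c2cc(C(=O)N[C@@H](C)c3nnc[nH]3)cc(-c3ncccc3F)c2)nc1`: 98.8%
- compound 2 `Cc1ccc(-c2cc(C(=O)N[C@H](C)c3ccc(C(F)(F)F)[n+]([O-])c3)cc(-c3ncccc3F)c2)nc1`: 95.2%

Compound 2, at 95.2%, has the larger free fraction of the two. Compound 1, at 98.8%, leaves less free, and this gap lies beyond the usual scatter of this assay.

Compound 3 `Cc1ccc(-c2cc(C(=O)N[C@H](C)c3ccc(F)c[n+]3[O-])cc(-c3ncccc3F)c2)nc1` has not yet been measured. Its change from compound 2 is a group of 8 heavy atoms (5 carbon, 1 nitrogen, 1 oxygen, 1 fluorine; one six-membered aromatic ring with 1 hetero atom) in place of a group of 11 heavy atoms (6 carbon, 1 nitrogen, 1 oxygen, 3 fluorine; one six-membered aromatic ring with 1 hetero atom), on a saturated chain carbon bound to an amide-type nitrogen and a saturated chain carbon. The two measured compounds differ in more than one place, so no measured step sizes this change directly, and any forecast is a judgement. A smaller group enters, and the expected change, towards more free compound and beyond the scatter, is a 2.9-fold higher unbound fraction from compound 2 to compound 3 (0.46 log units; beyond the scatter). For compound 3 the estimated value is 86%, with an expected range from 68% to 95%.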

Compound 3, plasma protein binding: 90.4%
Compound 3: middle estimate off by 1.5-fold (0.16 log units) (unbound fraction), on the high side; the measured number falls inside the stated range.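

In this assay, putting the group of 8 heavy atoms in place of the group of 11 heavy atoms on the saturated chain carbon gives a 2.0-fold higher unbound fraction from compound 2 to compound 3 (0.30 log units; within the scatter) and so this trim leaves binding at a level that repeat measurements cannot tell apart. A clearer shift appears on the amide-type nitrogen, where a group with a six-membered aromatic ring replaces a group with a five-membered aromatic ring and gives an 8.0-fold higher unbound fraction from compound 1 to compound 3 (0.90 log units; beyond the scatter) and this step lies beyond the scatter. Nothing measured here explains either step.

As far as these compounds go, whether a quite different group in this place, such as an amine or a carboxylic acid, would leave more compound free stays open. So does whether the ring itself or the other atoms of the group account for the larger step.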